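Chloro to methylsulfanyl exchange on two related cores

A few compounds are considered here, and "the series" means these few. Any claim that something is new, unique, unknown or untested is made for them only; others in the source may bear on it.

Compound 1 `CNC1=C(Cl)C(=O)c2ncccc2C1=O` and compound 2 `CNC1=C(Cl)C(=O)c2cccnc2C1=O` share the same atoms joined differently; the difference between the two cores is not broken down here. In an ADME assay on cells (T-cell, Homo sapiens) for antiproliferative activity, read by MTT assay, with a stated time of 48 h (a higher number here means a weaker inhibitor, a lower number a stronger inhibitor), compound 1 gives 3560 nM, and compound 2 gives 5210 nM, which lies within the scatter of compound 1. Compound 3 `CNC1=C(SC)C(=O)c2ncccc2C1=O` differs from compound 1 by methylsulfanyl in place of chloro on a double-bonded ring carbon. In this assay compound 3 gives 19500 nM, so the change made a 5.5-fold higher number from compound 1 to compound 3 (0.74 log units; beyond the scatter). Compound 4 `CNC1=C(SC)C(=O)c2cccnc2C1=O` has not been measured; it differs from compound 2 by methylsulfanyl in place of chloro on a double-bonded ring carbon, the same change at a place described in the same words. The step from compound 2 to compound 4 is expected to be a 5.0-fold higher number from compound 2 to compound 4 (0.70 log units; beyond the scatter), resting on the one earlier case because a 5.5-fold higher number from compound 1 to compound 3 (0.74 log units; beyond the scatter) was seen on the other core. Compound 4 is therefore estimated at 26000 nM in this assay, expected to fall between 10000 nM and 70000 nM.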

Compound 4, half-maximal inhibitory concentration: 7570 nM
Estimate against measurement, compound 4: 3.4-fold (0.54 log units) above; measured number outside the range, below it.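

On the core of compound 2, methylsulfanyl in place of chloro gives a 1.5-fold higher number from compound 2 to compound 4 (0.16 log units; within the scatter) in this assay, so the clear rise seen on the core of compound 1 does not carry over. The size of this step therefore depends on the core: the same change on two cores in this assay, a 5.5-fold higher number (0.74 log units; beyond the scatter) from compound 1 to compound 3 and a 1.5-fold higher number (0.16 log units; within the scatter) from compound 2 to compound 4, 3.8-fold (0.58 log units) apart, beyond the scatter of two such steps. Going by these compounds alone, with one pair on each core, this shows only that the step cannot be assumed to transfer between these two cores; it does not show what in the cores sets the difference, or how a further core would respond.

Open, on these data alone, is whether an amine or a methoxy group on the same ring carbon would also separate the two cores. Also open, as far as these compounds go, is whether a longer chain in place of the methyl of the methylamino group would alter this difference.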